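A few compounds are considered here, and "the series" means these few. Any claim that something is new, unique, unknown or untested is made for them only; others in the source may bear on it.

In an ADME assay on L02 cells (Homo sapiens) for cytotoxicity, read by MTT assay, with a stated time of 48 h (a lower number here means a stronger inhibitor, a higher number a weaker inhibitor), compound 1 (`CCN(CC)CCNC(=O)c1ccc(C(CC)(CC)c2ccc(OCC(=O)C(C)(C)C)c(C)c2)n1CC`) gives 2500 nM and compound 2 (`CCN(CC)CCNC(=O)c1ccc(C(CC)(CC)c2ccc(OCC(O)C(C)(C)C)c(C)c2)n1CC`) gives 2500 nM, so the two stand level at the highest number of the three measured. Compound 3 (`CCn1c(C(=O)NCCCN(C)C)ccc1C(CC)(CC)c1ccc(OCC(O)C(C)(C)C)c(C)c1`) gives 470 nM. The next case is compound 4 (`CC[C@@H](C)[C@H](NC(=O)c1ccc(C(CC)(CC)c2ccc(OCC(=O)C(C)(C)C)c(C)c2)n1CC)C(=O)O`), which differs from compound 1 as follows: 1-carboxy-2-methylbutyl in place of 2-(diethylamino)ethyl on an amide-type nitrogen. In short, 1-carboxy-2-methylbutyl stands in place of 2-(diethylamino)ethyl on an amide-type nitrogen.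

Two measured steps are available. The first, no change at the digits printed from compound 1 to compound 2 (within the scatter), swaps (tert-butyl)carbonyl for 1-hydroxy-2,2-dimethylpropyl, away from the chain in question, and offers little guidance here. The second, a 5.3-fold lower number from compound 2 to compound 3 (0.73 log units; beyond the scatter), is the closer guide, as it falls within the chain on the amide-type nitrogen. That step only exchanges one amino-bearing chain for another, whereas the change to compound 4 removes the diethylamino group entirely. Among the measured compounds shown here, no measured compound carries a carboxy group, so both size and direction are extrapolated. A step of about the same modest size is expected, towards a higher number, and this direction remains a judgement. The expected shift is a 4.8-fold higher number from compound 1 to compound 4 (0.68 log units; beyond the scatter). For compound 4, the estimated value is 12000 nM, with an expected range of 3500 nM to 40000 nM.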

Compound 4, half-maximal inhibitory concentration: 1500 nM
Compound 4: the middle estimate sits 8.0-fold (0.90 log units) above what was measured; measured number below the stated range.
By their numbers in this assay, from the lowest: compound 3; then compounds 4, 1 and 2 (each within the scatter of the next).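

In this assay the exchange of 2-(diethylamino)ethyl for 1-carboxy-2-methylbutyl on the amide-type nitrogen gives a 1.7-fold lower number from compound 1 to compound 4 (0.22 log units; within the scatter) and so stays inside the usual scatter. Among the compounds shown here, this adds something the earlier compounds could not show: with the (tert-butyl)carbonyl group kept in place, a chain without any amino group and with a carboxy group can sit on this nitrogen and leave the number in the same range as that of compound 1, whereas the only earlier change in this chain, a 5.3-fold lower number from compound 2 to compound 3 (0.73 log units; beyond the scatter), swapped one amino-bearing chain for another and lay beyond the scatter. Nothing on hand explains why the larger change in the chain leaves the number in place while the exchange between amino-bearing chains does not.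

As far as these compounds go, it remains open whether a shorter carboxylic acid chain such as carboxymethyl, an uncharged 2-hydroxyethyl chain or a simple primary amine on the same nitrogen would also stand level with compound 1. Also open, from the compounds shown here alone, are whether the other stereoisomers of 1-carboxy-2-methylbutyl read the same and whether this chain behaves alike when paired with the 1-hydroxy-2,2-dimethylpropyl group of compound 2.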